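The compounds below may be only part of what the source reports. "The series", "measured", "known", "first", "only" and "open" are said of these compounds alone.

Compound 1 `CC(=O)N1N=C(c2ccc(F)cc2)CC1c1ccc2c(c1)OCCO2`: 53100 nM
Compound 2 `CC(=O)N1N=C(c2ccc(Br)cc2)CC1c1ccc2c(c1)OCCCO2`: 97000 nM
Compound 3 `CC(=O)N1N=C(c2ccc(C)cc2)CC1c1ccc2c(c1)OCCCO2`: 89700 nM

In a functional assay on B16-F10 cells (Mus musculus) for antiproliferative activity, read by MTT assay, with a stated time of 48 h (a higher number here means a weaker inhibitor, a lower number a stronger inhibitor), compound 3 gives 89700 nM, and this value lies within the usual scatter of those of the other two compounds. The next compound, compound 4 `COc1ccc(C2=NN(C(C)=O)C(c3ccc4c(c3)OCCCO4)C2)cc1`, has not yet been measured. It keeps everything in compound 3 except one group, with methoxy in place of methyl on an aromatic carbon, para to a large group: methoxy in place of methyl on an aromatic carbon.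

Among the compounds with values here, only one measured step bears directly on this change. It is an exchange at the same place, methyl in place of bromo, and it gives a 1.1-fold lower number from compound 2 to compound 3 (0.03 log units; within the scatter). That is a single step, so it offers limited guidance, but it gives no reason to expect a large shift in this assay. No step beyond the scatter is therefore expected, and no direction can be favoured. The expected step is a 1.1-fold lower number from compound 3 to compound 4 (0.02 log units; within the scatter). The estimated value for compound 4 is 85000 nM, with an expected range of 45000 nM to 150000 nM.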

Compound 4, half-maximal inhibitory concentration: 85300 nM
Beside the measured number, compound 4's estimate is 1.0-fold (0.00 log units) below it, and the stated range covers the measured number.
By their numbers in this assay, from the lowest: compounds 1, 4, 3 and 2 (each within the scatter of the next).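

In this assay, the change from 4-methylphenyl to 4-methoxyphenyl gives a 1.1-fold lower number from compound 3 to compound 4 (0.02 log units; within the scatter), and methoxy in place of bromo gives a 1.1-fold lower number from compound 2 to compound 4 (0.06 log units; within the scatter). Bromo, methyl and methoxy have now all been read at this one position on an otherwise identical core, and no step among them leaves the scatter, so the earlier single step no longer stands alone; even the entry of a group with one hydrogen-bond acceptor leaves the number unmoved within that scatter. No measurement at hand offers an explanation for this flat picture.

On these data alone, whether a group of another kind at this position, such as an amine or a carboxylic acid, would produce a step beyond the scatter remains open. Also open, as far as these compounds go, is whether these same exchanges would read alike on the core of compound 1.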